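Plasma binding in the series: removing one methoxy

This account rests on a few compounds, and the source may have more. Where it says the series, first, only, none or still open, it means among the compounds named here.

Measured in an ADME assay on a cell-free system (plasma, Mus musculus) for protein binding:
- compound 1 `CNc1nccc(N2CC[C@H](NC(=O)Nc3cc(OC)cc(OC)c3)C2)n1`: 96.9%
- compound 2 `CNc1nccc(N2CC[C@H](NC(=O)Nc3ccc(CN4CCC4)c(C(F)(F)F)c3)C2)n1`: 85.6%

Of these two compounds, compound 1 has the lower unbound fraction, and its gap to compound 2 lies beyond the usual scatter. Going by the values given here, with only two values, this says little about the series as a whole.

The next compound to be measured is compound 3 `CNc1nccc(N2CC[C@H](NC(=O)Nc3cccc(OC)c3)C2)n1`, which carries hydrogen in place of methoxy on an aromatic carbon. The rest of the structure of compound 1 is unchanged.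

Among the compounds with values here, no two measured compounds differ in one place only, so the data give no direct measure of this change. Compound 1 stands high at 96.9%, leaving little room for more binding, so a modest move towards more free compound is expected in this assay, possibly not beyond the scatter. The expected step a 1.8-fold higher unbound fraction from compound 1 to compound 3 (0.25 log units; within the scatter) is therefore small.

For compound 3 the estimated value is 94.5%, with an expected range of 89% to 97.5%.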

Compound 3, plasma protein binding: 91.6%
The estimate for compound 3 lay 1.5-fold (0.18 log units) (unbound fraction) below the measured number, and the stated range covers the measured number.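

In this assay, the series now has its first step between compounds that differ in one place: hydrogen in place of methoxy on an aromatic carbon, meta to a large group and meta to a methoxy group, gives a 2.7-fold higher unbound fraction from compound 1 to compound 3 (0.43 log units; beyond the scatter), so this single change moves the read-out beyond the scatter. Going by these compounds alone, the size of this step is the first direct reading for this position, and with the other methoxy still present, compound 3 gives 91.6%, so binding to plasma protein remains high after the change. Nothing available bears on the origin of this step, which stands here as an observation only.

As a single step on a single pair, it does not show whether the shift is specific to methoxy at this aromatic carbon, or whether a chlorine atom, a hydroxyl group or a carboxylic acid in the same place would give a similar reading. It also leaves open whether replacing the remaining methoxy with hydrogen would add a second step of similar size.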